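The source may report more compounds than this note shows. Statements on the series, on what has been measured and on what is new or still open speak of the compounds shown alone.

Compound 1 `O=C1OC(c2ccccc2)C(c2ccc(O)cc2)=C1O` is the simplest of the group. In an assay on blood for inhibition of Polyunsaturated fatty acid 5-lipoxygenase (Homo sapiens), tested at 100 uM (on this read-out higher numbers stand for a stronger effect at the one concentration tested and lower numbers for a weaker effect), compound 1 gives 18.6%. Compound 2 `O=C1OC(c2ccc(OCc3ccccc3)cc2)C(c2ccc(O)cc2)=C1O` has no number in this assay; its result stands as "not determined" (no result reported). For the measured compounds named here, compound 3 `O=C1OC(c2ccc(O)c(O)c2)C(c2ccc(O)cc2)=C1O` gives 79.5% in this assay, the higher of the two numbers known, and its gap to compound 1 is well beyond the usual scatter of repeated measurements.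

Compound 4 `O=C1OC(c2ccc(O)cc2)C(c2ccc(O)cc2)=C1O` has not yet been measured. It differs from compound 3 by hydrogen in place of hydroxy on an aromatic carbon. Going by the values given here, no measured pair shows this exact change, so its size must be guessed from the surroundings: compound 1, which carries neither hydroxy group on that ring, sits far below compound 3.

Because compound 3 gives 79.5% while compound 1 gives only 18.6%, compound 4 is expected to fall between them, at about 38%. The estimate for compound 4 is judged likely to lie between 15% and 62%. The expected step from compound 3 to compound 4 is a fall of a number 41.5 percentage points lower from compound 3 to compound 4 (beyond the scatter), beyond the scatter.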

Compound 4, a percentage reported as activity, at one concentration (the size of the read-out at that concentration, not a potency): 27.8%
For compound 4 the middle estimate is 10.2 percentage points above the measured one; the measured number falls inside the stated range.
By their numbers in this assay, from the lowest: compounds 1 and 4 (each within the scatter of the next); then compound 3.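

In this assay, taking away the hydroxy group that sits ortho to a hydroxy group gives a number 51.7 percentage points lower from compound 3 to compound 4 (beyond the scatter), a large step from a change of a single atom. The other single change on this ring, hydroxy in place of hydrogen, gives a number 9.2 percentage points higher from compound 1 to compound 4 (within the scatter), so the same swap counts for little on the unsubstituted ring of compound 1 but for a great deal when it sits ortho to a hydroxy group. Nothing measured here explains this difference.

The compounds shown leave open whether another group at this place, such as a methoxy group or an amine, could stand in for the hydroxy group and keep the effect. With no number for compound 2, they also say nothing about how a benzyloxy group on this ring affects the read-out.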